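A few compounds are considered here, and "the series" means these few. Any claim that something is new, unique, unknown or untested is made for them only; others in the source may bear on it.

For the measured compounds named here, the three compounds measured so far share one core and differ only in the group attached to a carbonyl carbon: compound 1 `Cc1ccc(S(=O)(=O)N[C@@H](CC(=O)NC(C)(C)C)C(=O)NCCNC(=O)Nc2ccccc2)cc1`, compound 2 `Cc1ccc(S(=O)(=O)N[C@@H](CC(=O)NC(C)(C)C)C(=O)NCCNC(=O)c2ccccc2F)cc1` and compound 3 `COc1cc(OC)cc(C(=O)NCCNC(=O)[C@H](CC(=O)NC(C)(C)C)NS(=O)(=O)c2ccc(C)cc2)c1`. In an ADME assay on Karpas-1106P cells (Homo sapiens) for cytotoxicity (a lower number here means that less compound is needed, a higher number that more compound is needed for the effect), compound 1 reaches only the limit of the assay, > 11100 nM. Compound 2 likewise stops at a limit, > 11100 nM. Compound 3 also gives no number but a limit, > 11100 nM. As a result the step that the two limits leave unreadable from compound 1 to compound 2 cannot be read, and the same holds for a step that the two limits leave unreadable from compound 1 to compound 3 and a step that the two limits leave unreadable from compound 2 to compound 3, because the limit of > 11100 nM in this assay, at which 3 of the 3 values shown sit, is where every value seen so far sits. Compound 3 therefore stands nowhere apart from its two neighbours; the three rest together at the same limit.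

Going by the values given here, compound 4 `C#Cc1cccc(C(=O)NCCNC(=O)[C@H](CC(=O)NC(C)(C)C)NS(=O)(=O)c2ccc(C)cc2)c1` is the next member of the series. 3-ethynylphenyl in place of 3,5-dimethoxyphenyl on a carbonyl carbon None of the measured steps gives a readable size for an exchange of the aryl group on this carbonyl carbon, so there is no foundation for expecting a rise or a fall. Compound 4 is expected to behave like its neighbours, with a step that the limit leaves unreadable from compound 3 to compound 4 that is expected to stay within the scatter. Compound 4 is estimated at 20000 nM, in the range 8000 nM to 60000 nM.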

Compound 4, half-maximal effective concentration: > 11100 nM
Compound 4 ended at the assay's limit; the forecaster's own chance of this, stated with the estimate: 85%; the middle value lies beyond the limit too.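

In this assay compound 4 also gives no number but a limit, > 11100 nM. For the compounds shown here, no step from compound 1, compound 2 or compound 3 to compound 4 can be read, because all four compounds rest at the same point: the limit of > 11100 nM in this assay, at which 4 of the 4 values shown sit. The compounds shown leave open how the group on this carbonyl carbon affects this assay, since none yields a number.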